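A few compounds are considered here, and "the series" means these few. Any claim that something is new, unique, unknown or untested is made for them only; others in the source may bear on it.

Three compounds of the shared core differ only in the group on the saturated chain carbon bound to a sulfur. In an assay on CHO cells for displacement of a labelled ligand from adenosine receptor A3 (Homo sapiens), read by scintillation counting, with a stated time of 120 min, tested at 1 uM (a higher number here means more inhibition at the concentration tested (going by the name of the read-out), a lower number less inhibition), compound 1 `N#Cc1c(N)nc(SCC(N)=O)c(C#N)c1-c1ccc(OCC2CC2)cc1` gives 8%; compound 2 `N#Cc1c(N)nc(SCn2cncn2)c(C#N)c1-c1ccc(OCC2CC2)cc1` gives 1%; compound 3 `N#Cc1c(N)nc(SCC(=O)NO)c(C#N)c1-c1ccc(OCC2CC2)cc1` gives 31%, the highest of the three, with a number 23 percentage points higher from compound 1 to compound 3 (beyond the scatter) and a number 30 percentage points higher from compound 2 to compound 3 (beyond the scatter), while a number 7 percentage points lower from compound 1 to compound 2 (within the scatter). Compound 4 `COC(=O)CSc1nc(N)c(C#N)c(-c2ccc(OCC3CC3)cc2)c1C#N` is not yet measured. It differs from compound 3 by methoxy in place of hydroxyamino on a carbonyl carbon. The step that bears on this is a number 23 percentage points higher from compound 1 to compound 3 (beyond the scatter), where the hydroxy on the amide-type nitrogen, absent in compound 4, accompanied the rise; a fall back toward the level of compound 1 is therefore expected. The expected step is a number 21 percentage points lower from compound 3 to compound 4 (beyond the scatter). Compound 4 is estimated at 10%, within a range of 0% to 25%.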

Compound 4, a percentage reported as inhibition, at one concentration (the size of the read-out at that concentration, not a potency): 1%
Estimate against measurement, compound 4: 9 percentage points above; measured number inside the range.
By their numbers in this assay, from the lowest: compounds 2, 4 and 1 (each within the scatter of the next); then compound 3.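

In this assay, methoxy in place of hydroxyamino on a carbonyl carbon gives a number 30 percentage points lower from compound 3 to compound 4 (beyond the scatter), whereas methoxy in place of amino gives a number 7 percentage points lower from compound 1 to compound 4 (within the scatter) and methoxycarbonyl in place of 1H-1,2,4-triazol-1-yl gives no change at the digits printed from compound 2 to compound 4 (within the scatter). Among these four groups, only hydroxycarbamoyl stands apart, now against three neighbours that lie within the scatter of one another. No measurement at hand accounts for this separation.

From the compounds shown here alone, whether the rise belongs to hydroxyamino specifically remains open; a carboxylic acid or methoxyamino on the same carbonyl carbon would test this. Potency also remains open, since each number is a read-out at one concentration.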